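The source may report more compounds than this note shows. Statements on the series, on what has been measured and on what is new or still open speak of the compounds shown alone.

In a functional assay on the whole organism (strain albino) for inhibition, with Rattus norvegicus as the target, read by paw edema, with stated times of 30 min and 4 h, at a dose of 0.28 mmol/kg by the oral route (on this read-out lower numbers stand for less inhibition and higher numbers for more inhibition at the one dose given (going by the name of the read-out)), compound 2 `C=CCn1c(SCC(=O)Nc2ccc(/C(C)=N/O)cc2)nnc1-c1cc(OC)c(OC)c(OC)c1` gives 72%, and compound 1 `C=CCn1c(SCC(=O)Nc2ccc(C(C)=O)cc2)nnc1-c1ccc(OC)c(OC)c1` gives 70% in this assay; the two numbers lie within the scatter of each other, so compound 2 cannot be set apart from compound 1 on this read-out. Compound 3 `C=CCn1c(SCC(=O)Nc2ccc(C(C)=O)cc2)nnc1-c1cc(OC)c(OC)c(OC)c1` has not yet been measured. It differs from compound 2 in one place: a group of 3 heavy atoms (2 carbon, 1 oxygen; no ring) in place of a group of 4 heavy atoms (2 carbon, 1 nitrogen, 1 oxygen; no ring), on an aromatic carbon. Going by the values given here, no measured pair shows this change directly, but the acetyl that enters is the group carried by compound 1, whose 70% sits close to the value of compound 2. The step of a number 2 percentage points lower from compound 2 to compound 3 (within the scatter) is therefore expected to be none beyond the scatter. Compound 3 is estimated at 70%, within 58% to 82%.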

Compound 3, a percentage reported as inhibition, in the whole organism at one dose (the size of the read-out at that dose, not a potency): 68%
Compound 3: middle estimate off by 2 percentage points, on the high side; low and high end bracket the measured number.
By their numbers in this assay, from the lowest: compounds 3, 1 and 2 (each within the scatter of the next).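

In this assay, acetyl in place of the larger group on the aromatic carbon, para to a large group, gives a number 4 percentage points lower from compound 2 to compound 3 (within the scatter), so at this position the change, which also removes a hydrogen-bond donor, shows no effect beyond the scatter. Methoxy in place of hydrogen on an aromatic carbon gives a number 2 percentage points lower from compound 1 to compound 3 (within the scatter), so this change also stays within the scatter. Nothing available explains either result. The compounds shown leave open whether an amine or a carboxylic acid at this position would shift the read-out beyond the scatter.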